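Swapping fluoro for hydrogen: how much should it matter?

The compounds below may be only part of what the source reports. "The series", "measured", "known", "first", "only" and "open" are said of these compounds alone.

In a functional assay on T98G cells (Homo sapiens) for cytotoxicity, read by MTT assay, with a stated time of 48 h (a higher number here means a weaker inhibitor, a lower number a stronger inhibitor), compound 3 `C/C(=N\NC(=S)Nc1ccccc1F)c1ccccn1` gives 3.1 nM. Going by the values given here, that sits at the low end of the numbers so far, within the usual scatter of compound 1 `C/C(=N\NC(=S)Nc1ccc(Cl)cc1)c1ccccn1`, which gives 5.9 nM. Compound 2 `C/C(=N\NC(=S)Nc1ccc(I)cc1)c1ccccn1` stands well apart from both at 64 nM.

The next compound, compound 4 `C/C(=N\NC(=S)Nc1ccccc1)c1ccccn1`, differs from compound 3 in one place: hydrogen in place of fluoro on an aromatic carbon. In short, hydrogen takes the place of fluoro on an aromatic carbon, ortho to a large group.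

Among the compounds with values here, only one measured step offers any guidance. This is an 11-fold higher number from compound 1 to compound 2 (1.04 log units; beyond the scatter), a large change in which iodo replaces chloro. It shows that a single swap on the aromatic ring can matter a great deal in this assay. However, it involves neither fluoro nor hydrogen, so it is a weak guide to size here and says nothing firm about direction.

Within the data shown here, a small step is therefore expected, most likely toward a higher number, since no other measured compound gives a clearly lower number than compound 3 at 3.1 nM. The expected change is a 1.9-fold higher number from compound 3 to compound 4 (0.29 log units; within the scatter). The estimate for compound 4 is 6 nM, with an expected range from 1.5 nM to 30 nM.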

Compound 4, half-maximal inhibitory concentration: 6.81 nM
Compound 4: middle estimate off by 1.1-fold (0.05 log units), on the low side; the measured number falls inside the stated range.
By their numbers in this assay, from the lowest: compounds 3, 1 and 4 (each within the scatter of the next, the first and the last beyond it); then compound 2.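

With compound 4, the carbon ortho to a large group carries a plain hydrogen, giving a baseline for judging what each halogen does in this assay. Fluoro at this position makes a modest but real difference to the number (a 2.2-fold higher number from compound 3 to compound 4 (0.34 log units; beyond the scatter)). The same baseline separates the two other halogens on the aromatic ring: chloro cannot be told apart from hydrogen (a 1.2-fold higher number from compound 1 to compound 4 (0.06 log units; within the scatter)), while iodo stands clearly apart from it (a 9.4-fold lower number from compound 2 to compound 4 (0.97 log units; beyond the scatter)), so among these compounds the earlier large gap between chloro and iodo traces to the iodo compound alone.

As far as these compounds go, whether an amine, a methoxy group or a nitrile on that same ring carbon would move the number further in either direction remains open, as three halogens and hydrogen are too few to show a trend. Nothing measured alongside these numbers offers an explanation for why the steps differ in size.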